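Compound 4 Expected To Sit Close To Compound 3

A few compounds are considered here, and "the series" means these few. Any claim that something is new, unique, unknown or untested is made for them only; others in the source may bear on it.

In a functional assay on MCF7 cells (Homo sapiens) for antiproliferative activity, read by MTT assay, with a stated time of 24 h, tested at 1 ug/mL (on this read-out lower numbers stand for a stronger effect and higher numbers for a weaker effect at the one concentration tested), compound 1 `O=Cc1cn(-c2ccccc2)nc1-c1ccccc1O` gives 79%. Compound 2 `COc1cc(/C=C/C(=O)C(=Cc2cn(-c3ccccc3)nc2-c2ccc([N+](=O)[O-])cc2)C(=O)/C=C/c2ccc(O)c(OC)c2)ccc1O` gives 90%, and compound 3 `COc1cc(/C=C/C(=O)C(=Cc2cn(-c3ccccc3)nc2-c2ccccc2O)C(=O)/C=C/c2ccc(O)c(OC)c2)ccc1O` gives 88%. On these three numbers compound 3 stands second highest, yet its nearest neighbour is compound 2 and the furthest is compound 1, both within the scatter, so the three cannot really be told apart. Going by the values given here, the only measured single change, a number 2 percentage points lower from compound 2 to compound 3 (within the scatter), swapped 4-nitrophenyl for 2-hydroxyphenyl on an aromatic carbon and left the number where it was.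

Compound 4 `COc1cc(/C=C/C(=O)C(=Cc2cn(-c3ccccc3)nc2-c2ccc(Cl)cc2)C(=O)/C=C/c2ccc(O)c(OC)c2)ccc1O` has not been measured yet. It differs from compound 3 in one place: 4-chlorophenyl in place of 2-hydroxyphenyl on an aromatic carbon. Among the compounds with values here, the one measured step that touches this same place is a number 2 percentage points lower from compound 2 to compound 3 (within the scatter), and it stayed within the scatter. Nothing measured here shows how 4-chlorophenyl behaves at that place, so the expectation rests on that single step alone. The step expected from this change, no change at the digits printed from compound 3 to compound 4 (within the scatter), is therefore none beyond the scatter. Compound 4 is estimated in this assay at 88%, with a range from 76% to 98%.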

Compound 4, a percentage reported as activity, at one concentration (the size of the read-out at that concentration, not a potency): 65%
Estimate against measurement, compound 4: 23 percentage points above; measured number outside the range, below it.
By their numbers in this assay, from the lowest: compound 4; then compounds 1, 3 and 2 (each within the scatter of the next, the first and the last beyond it).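

In this assay, the aromatic carbon next to the ring nitrogen now proves sensitive to the group it carries: 4-chlorophenyl in place of 2-hydroxyphenyl gives a number 23 percentage points lower from compound 3 to compound 4 (beyond the scatter), whereas the earlier change at this carbon gave only a number 2 percentage points lower from compound 2 to compound 3 (within the scatter). The second comparison keeps the phenyl ring and alters only its substituent, and chloro in place of nitro gives a number 25 percentage points lower from compound 2 to compound 4 (beyond the scatter), so on these compounds a single group on that ring is enough to move the number towards a stronger effect, while 2-hydroxyphenyl and 4-nitrophenyl remain within the scatter of each other. Nothing available explains why the 4-chlorophenyl compound stands apart from the other two, and the counts of hydrogen-bond donors and acceptors that differ between compound 3 and compound 4 are only a description of the change, not a cause.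

The compounds shown leave open whether chloro is special or whether 4-bromophenyl, 4-methylphenyl or a phenyl ring carrying an amine would reach a similar number. They also leave open how far the effect of compound 4 extends across other concentrations, as a single tested concentration gives the size of a read-out and not a potency.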